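Chain Length on the Imidazole Nitrogen: Compound 3 to Compound 4

A few compounds are considered here, and "the series" means these few. Any claim that something is new, unique, unknown or untested is made for them only; others in the source may bear on it.

Compound 3 `Cc1nc(CN2CCN(c3cccc4[nH]c(-c5ccc(C(C)(C)C)cc5)nc34)CC2)cn1C` gives the lowest number of the three measured compounds in an assay on isolated protein for displacement of a labelled ligand from Gonadotropin-releasing hormone receptor (Rattus norvegicus) (on this read-out lower numbers stand for stronger inhibition and higher numbers for weaker inhibition), at 34 nM. Its nearest neighbour is compound 2 `CCCCn1cnc(CN2CCN(c3cccc4[nH]c(-c5ccc(C(C)(C)C)cc5)nc34)CC2)c1C`, which gives 49 nM; the step of a 1.4-fold lower number from compound 2 to compound 3 (0.16 log units; within the scatter) is within the scatter. Compound 1 `Cn1cnc(CN2CCN(c3cccc4[nH]c(-c5ccc(C(C)(C)C)cc5)nc34)CC2)c1` gives 98 nM, and the step of a 2.9-fold lower number from compound 1 to compound 3 (0.46 log units; beyond the scatter) is modest but beyond the scatter. Compound 4 `CCCn1cc(CN2CCN(c3cccc4[nH]c(-c5ccc(C(C)(C)C)cc5)nc34)CC2)nc1C` differs from compound 3 only by ethyl in place of hydrogen on a saturated chain carbon bound to an aromatic nitrogen. Among the compounds with values here, two measured steps bear on this change: a 2.0-fold lower number from compound 1 to compound 2 (0.30 log units; within the scatter), where a longer chain on the same aromatic nitrogen arrived together with an added methyl, and a 1.4-fold lower number from compound 2 to compound 3 (0.16 log units; within the scatter), where that longer chain was shortened again; both steps are within the scatter. Lengthening the chain on the aromatic nitrogen therefore appears to leave this assay largely unchanged, though only compounds 1, 2 and 3 support that reading. Compound 4 is accordingly expected to show a 1.1-fold lower number from compound 3 to compound 4 (0.05 log units; within the scatter), that is, no step beyond the scatter. The estimate for compound 4 in this assay is 30 nM, with a range from 12 nM to 80 nM.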

Compound 4, half-maximal inhibitory concentration in the Gonadotropin-releasing hormone receptor assay: 41 nM
Compound 4: middle estimate off by 1.4-fold (0.14 log units), on the low side, within the range that was stated.
By their numbers in the Gonadotropin-releasing hormone receptor assay, from the lowest: compounds 3, 4, 2 and 1 (each within the scatter of the next, the first and the last beyond it).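

Within the data shown here, in the Gonadotropin-releasing hormone receptor assay the step of a 1.2-fold higher number from compound 3 to compound 4 (0.08 log units; within the scatter) gives the first reading of ethyl in place of hydrogen on this saturated chain carbon bound to an aromatic nitrogen on its own, and in a physicochemical assay for solubility, at pH 7.4 (a higher number here means a more soluble compound, a lower number a less soluble compound), compound 3 gives 51 ug/mL and compound 4 gives 55 ug/mL and the same change gives a 1.1-fold higher number from compound 3 to compound 4 (0.03 log units; within the scatter), so neither read-out separates methyl from propyl here. In the Gonadotropin-releasing hormone receptor assay the step of a 1.2-fold lower number from compound 2 to compound 4 (0.08 log units; within the scatter) also stays within the scatter, while the step of a 2.4-fold lower number from compound 1 to compound 4 (0.38 log units; beyond the scatter) is modest but beyond it, so compound 4, like compound 3, stands apart from compound 1. No supporting data explain why this change moves either read-out so little.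

The compounds shown leave open whether this tolerance holds for a longer chain or a branched chain without the butyl-bearing compound's added methyl. They also leave open how a chain ending in an amine or a carboxylic acid would read in either assay.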